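Nitrophenyl for methoxyphenyl: working notes on compound 3

The source may report more compounds than this note shows. Statements on the series, on what has been measured and on what is new or still open speak of the compounds shown alone.

Measured so far:
compound 1, `COc1ccc(-c2cc(-c3cc(C(C)C)c(O)cc3C)[nH]c(=O)c2C#N)cc1`, 24%
compound 2, `COc1cc(OC)c(-c2cc(-c3cc(C(C)C)c(O)cc3C)[nH]c(=O)c2C#N)c(OC)c1`, 32%

Both were run in a functional assay for inhibition, tested at 20 ug/mL; on this read-out higher numbers stand for a stronger effect at the one concentration tested and lower numbers for a weaker effect. Among the compounds with values here, compound 1 gives 24%, the lower of the two numbers; compound 2 gives 32%, a gap that lies within the usual scatter, so the two values show no order between them and no step between measured compounds can be drawn.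

Compound 3, `Cc1cc(O)c(C(C)C)cc1-c1cc(-c2ccccc2[N+](=O)[O-])c(C#N)c(=O)[nH]1`, has not been measured. Relative to compound 1 the change is 2-nitrophenyl in place of 4-methoxyphenyl on an aromatic carbon. The pair measured so far alters a different part of the molecule and gives no guidance on this position, so nothing in the data points to a move in either direction beyond the scatter.

For compound 3 the expected value in this assay is 25%, with a range from 5% to 50%. The step of a number 1 percentage points higher from compound 1 to compound 3 (within the scatter) is therefore estimated to stay within the scatter.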

Compound 3, a percentage reported as inhibition, at one concentration (the size of the read-out at that concentration, not a potency): 20%
The estimate for compound 3 lay 5 percentage points above the measured number; measured number inside the range.
By their numbers in this assay, from the lowest: compounds 3, 1 and 2 (each within the scatter of the next, the first and the last beyond it).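

In this assay, within the data shown here, 2-nitrophenyl in place of 4-methoxyphenyl on the aromatic carbon ortho to a cyano group gives a number 4 percentage points lower from compound 1 to compound 3 (within the scatter), the first step that can be read at this position. The exchange of one substituted phenyl for another therefore produces no change beyond the scatter on this read-out, and the position tolerates this particular swap. No evidence at hand bears on this result, and no cause can be assigned to it.

The compounds shown cannot separate the change of substituent from its change of place on the phenyl ring. As far as these compounds go, it also remains open whether an amine or a carboxylic acid on that phenyl ring, or a simple alkyl chain in place of the ring, would shift the read-out beyond the scatter.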